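One Stereocentre Drawn on the Oxolane Side Chain

This account rests on a few compounds, and the source may have more. Where it says the series, first, only, none or still open, it means among the compounds named here.

In a functional assay on U-87MG ATCC cells for antiproliferative activity against U-87 MG (Homo sapiens), with a stated time of 5 days (on this read-out higher numbers stand for an effect only at larger amounts of compound and lower numbers for an effect already at smaller amounts), compound 1 `Nc1nc2cc(-c3nn(CC4OCCO4)c4ncnc(N)c34)ccc2o1` gives 100 nM. Compound 2 `Nc1nc2cc(-c3nn(CC4CCCO4)c4ncnc(N)c34)ccc2o1`, which carries oxolan-2-yl in place of 1,3-dioxolan-2-yl, gives 100 nM and so stands level with compound 1. Within the data shown here, that exchange is the only measured step, and it shows no change at the digits printed from compound 1 to compound 2 (within the scatter). Compound 3 `Nc1nc2cc(-c3nn(C[C@H]4CCCO4)c4ncnc(N)c34)ccc2o1` departs from compound 2 in one respect: the two compounds have the same atoms and bonds; at least one stereo element is drawn with a configuration in one of them and without one in the other: 1 of 1 stereo elements differ; a stereocentre at a saturated ring carbon is drawn without a configuration in compound 2 and R in compound 3. The measured step altered the ring itself and not a drawn configuration, so it bears on this change only indirectly. Among the measured compounds shown here, no measured pair tests the stereocentre, and the data offer no direction for any shift. A change beyond the scatter is therefore not expected, although the range is kept wide. The expected size is no change at the digits printed from compound 2 to compound 3 (within the scatter). For compound 3 the estimated value is 100 nM, with an expected range from 35 nM to 300 nM.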

Compound 3, half-maximal effective concentration: 100 nM
Estimate against measurement, compound 3: no gap at the digits printed; measured number inside the range.
By their numbers in this assay, from the lowest: compounds 1, 2 and 3 (each within the scatter of the next).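

In this assay, drawing the saturated ring carbon as R gives no change at the digits printed from compound 2 to compound 3 (within the scatter), so the defined form shows nothing that sets it apart from the compound drawn without a configuration. The only thing that separates this pair is a matter of drawing: the fact that one of compounds 2 and 3 is drawn with a defined configuration and the other without, at the place where they differ Set against the 1,3-dioxolan-2-yl side chain, the oxolan-2-yl group drawn as R also gives no change at the digits printed from compound 1 to compound 3 (within the scatter), so the earlier ring exchange holds when the configuration is defined.

Going by these compounds, what the S form would give remains open, and the drawing of compound 2 does not say whether it is a mixture of forms. On these data alone, it is also open how this read-out would respond to an amine such as pyrrolidin-2-yl on the same chain carbon, or to a longer chain carrying the oxolane ring.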